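The source may report more compounds than this note shows. Statements on the series, on what has been measured and on what is new or still open speak of the compounds shown alone.

Working notes on the series. Compound 1 `CN(C)C(=O)c1cc2cnc(Nc3ccc(NC(=O)C4(C(=O)Nc5cccc(Br)c5)CC4)cc3)nc2n1C1CCCC1` in a functional assay on T47D cells (Homo sapiens) for inhibition, read by CCK-8 assay, with a stated time of 72 h, tested at 10 uM (a higher number here means more inhibition of growth at the concentration tested, a lower number less inhibition of growth), gives 94.6%. Compound 2 `Cc1cccc(NC(=O)C2(C(=O)Nc3ccc(Nc4ncc5cc(C(=O)N(C)C)n(C6CCCC6)c5n4)cc3)CC2)c1` in this assay gives 95.3%. Among the measured compounds shown here, the single measured step, a number 0.7 percentage points higher from compound 1 to compound 2 (within the scatter), is within the scatter, so compound 2 stands alongside compound 1 at the top of the two numbers without being separated from it.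

Compound 3 `CN(C)C(=O)c1cc2cnc(Nc3ccc(NC(=O)C4(C(=O)Nc5ccc(Cl)cc5)CC4)cc3)nc2n1C1CCCC1` is not yet measured. Its change from compound 2 is 4-chlorophenyl in place of 3-methylphenyl on an amide-type nitrogen. For the measured compounds named here, the only measured step that bears on this region is a number 0.7 percentage points higher from compound 1 to compound 2 (within the scatter), which also swapped one substituent on the terminal aryl amide and moved nothing beyond the scatter. With both measured numbers near full inhibition, the expected step of a number 2.3 percentage points lower from compound 2 to compound 3 (within the scatter) is none beyond the scatter. For compound 3 in this assay the estimate is 93%, with a range from 84% to 98%.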

Compound 3, percent growth inhibition at one concentration: 95%
For compound 3 the middle estimate is 2 percentage points below the measured one; low and high end bracket the measured number.
By their numbers in this assay, from the lowest: compounds 1, 3 and 2 (each within the scatter of the next).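

In this assay, the change to 4-chlorophenyl on the amide-type nitrogen gives a number 0.3 percentage points lower from compound 2 to compound 3 (within the scatter) and a number 0.4 percentage points higher from compound 1 to compound 3 (within the scatter). The earlier pair compared only 3-bromophenyl and 3-methylphenyl, whereas this result shows that a 4-chlorophenyl group also leaves the reading unseparated from both, so no preference among these three aryl groups can be read at this concentration. Nothing available here bears on why these readings stay together.

Still open, as far as these compounds go, is whether a group of another kind on this amide-type nitrogen, such as a phenyl ring carrying a carboxylic acid or an amine, or a longer alkyl chain in place of the aryl group, would move the reading beyond the scatter. Also open, from the compounds shown here alone, is whether compounds 1, 2 and 3 would separate at other concentrations.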